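The source may hold more compounds than are shown below. What is called first, only, known or untested is meant among the compounds shown, and "the series" means these compounds.

Two pairs of compounds share one structural change. Compound 1 `CC1=NN(C2=NC(C)=C(C(=O)Nc3cccc([N+](=O)[O-])c3)C(c3ccc(O)cc3O)N2)C(=O)/C1=C/c1ccco1` and compound 2 `CC1=NN(C2=NC(C)=C(C(=O)Nc3cccc([N+](=O)[O-])c3)C(c3ccc(O)cc3O)N2)C(=O)/C1=C/c1cccs1` are built on one core, while compound 3 `CC1=C(C(=O)Nc2cccc([N+](=O)[O-])c2)C(c2ccc(O)cc2O)NC(NN2C(=O)/C(=C\c3ccco3)SC2=S)=N1` and compound 4 `CC1=C(C(=O)Nc2cccc([N+](=O)[O-])c2)C(c2ccc(O)cc2O)NC(NN2C(=O)/C(=C\c3cccs3)SC2=S)=N1` are built on another; the difference between the two cores is not broken down here. In a functional assay on HCT-116 cells (Homo sapiens) for inhibition, read by sulforhodamine B assay, with a stated time of 2 days (a higher number here means a weaker inhibitor of growth, a lower number a stronger inhibitor of growth), compound 1 gives only a limit of the assay, > 100000 nM. In this assay compound 2 gives 26500 nM. The change thiophen-2-yl in place of furan-2-yl on a double-bonded chain carbon bound to a double-bonded ring carbon made a step of an at least 3.7-fold lower number from compound 1 to compound 2 (0.57 log units; beyond the scatter). In this assay compound 3 gives only a limit of the assay, > 100000 nM. Compound 4 has not yet been measured; it carries the same change, (thiophen-2-yl in place of furan-2-yl on a double-bonded chain carbon bound to a double-bonded ring carbon), at the same place as in the first pair. For compound 4 the expected step is an at least 2.0-fold lower number from compound 3 to compound 4 (0.30 log units; that floor lies within the scatter), which rests on compound 2 with its value 26500 nM and on the step of an at least 3.7-fold lower number from compound 1 to compound 2 (0.57 log units; beyond the scatter) in the first core. Because (the limit of > 100000 nM in this assay, at which 2 of the 3 values shown sit), the starting point in the second core is itself only a limit, so the size of the step there is uncertain. Compound 4 is therefore estimated at 50000 nM, within a range from 15000 nM to 150000 nM.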

Compound 4, concentration for 50% growth inhibition: 4500 nM
Estimate against measurement, compound 4: 11-fold (1.05 log units) above; the measured number lies below the stated range.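

On the second core, thiophen-2-yl in place of furan-2-yl again gave a stronger inhibitor of growth in this assay, with a step of an at least 22-fold lower number from compound 3 to compound 4 (1.34 log units; beyond the scatter), so the direction of the change carried over in both pairs shown. Whether its size carried over as well stays unsettled, since the two steps can only be set side by side as floors: the same change on two cores in this assay, an at least 3.7-fold lower number (0.57 log units; beyond the scatter) from compound 1 to compound 2 and an at least 22-fold lower number (1.34 log units; beyond the scatter) from compound 3 to compound 4; the limit leaves it open whether they differ. Both furan-2-yl compounds give no exact starting value, and two pairs make no rule for the whole series: the limit of > 100000 nM in this assay, at which 2 of the 4 values shown sit.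

The compounds shown leave open whether a different ring at this place, such as phenyl or pyridin-2-yl, would follow the same direction on both cores. They also leave open how the thiophen-2-yl compounds would respond if the nitro group were replaced by an amine or a carboxylic acid.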